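This account rests on a few compounds, and the source may have more. Where it says the series, first, only, none or still open, it means among the compounds named here.

Measured compounds in a physicochemical assay for lipophilicity, read by LC-MS, in phosphate buffer, measured as octanol-water partition, at pH 7.4, tested at 66.7 uM; on this read-out higher numbers stand for higher lipophilicity and lower numbers for lower lipophilicity:
- compound 1 `Cc1ccc(-c2ccnc(Nc3ccc(N4CCN(C)CC4)c(C(F)(F)F)c3)n2)cc1` gives > 5.85, which is a limit of the assay.
- compound 2 `CN1CCN(c2ccc(Nc3nccc(-c4cccc(Cl)c4)n3)cc2C(F)(F)F)CC1` gives > 6, also a limit.
- compound 3 `CN1CCN(c2ccc(Nc3nccc(-c4ccc5ccccc5c4)n3)cc2C(F)(F)F)CC1` gives > 5.7, again a limit.

Compound 3 therefore stands only at a limit on this read-out, as do the two other values shown: the limit of > 5.7 in this assay, at which 1 of the 3 values shown sits, the limit of > 5.85 in this assay, at which 1 of the 3 values shown sits, and (the limit of > 6 in this assay, at which 1 of the 3 values shown sits). All three measured steps between these compounds, a step that the two limits leave unreadable from compound 1 to compound 2, a step that the two limits leave unreadable from compound 1 to compound 3 and a step that the two limits leave unreadable from compound 2 to compound 3, cannot be read, so none of them gives a size or direction for a further change at the same position.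

Compound 4 `CN1CCN(c2ccc(Nc3nccc(-c4cccc([N+](=O)[O-])c4)n3)cc2C(F)(F)F)CC1` has not yet been measured. The change from compound 3 is 3-nitrophenyl in place of naphthalen-2-yl on an aromatic carbon. Among the measured compounds shown here, no measured step bears on this change in a readable way, so the expected size of the step rests on the structural change alone. Compound 4 is expected to fall below the limits seen so far, to a value that the assay can read, and the step of a number at least 0.70 log units lower from compound 3 to compound 4 (beyond the scatter) is expected to run downward. The estimate for compound 4 is 5, with a range from 4.3 to 5.8.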

Compound 4, distribution coefficient: 4.5
Beside the measured number, compound 4's estimate is 0.50 log units above it; the range from low to high includes it.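

In this assay, among the compounds shown here, compound 4 gives the first readable number at this position on the aromatic carbon next to the ring nitrogen, and 3-nitrophenyl in place of naphthalen-2-yl gives a number at least 1.20 log units lower from compound 3 to compound 4 (beyond the scatter). Nitro in place of chloro gives a number at least 1.50 log units lower from compound 2 to compound 4 (beyond the scatter), and 3-nitrophenyl in place of 4-methylphenyl gives a number at least 1.35 log units lower from compound 1 to compound 4 (beyond the scatter), so all three changes run downward. Each size is only a minimum, with its upper end resting on a limit, and for compound 3 that limit is: the limit of > 5.7 in this assay, at which 1 of the 4 values shown sits.

From the compounds shown here alone, whether an amine, a carboxylic acid or a nitrile on the same phenyl ring would also give a readable number remains open. Going by these compounds, the steps among compound 1, compound 2 and compound 3 cannot be read, so the order of these three also remains open.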